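The compounds below may be only part of what the source reports. "The series", "measured", "known", "first", "only" and "open" are said of these compounds alone.

Compound 1, `COc1ccccc1N1CCN(CCNc2c(C(=O)C(C)C)c(-c3ccccc3)nn(C)c2=O)CC1`, is the stronger of two compounds measured in an assay on isolated protein for binding affinity to Alpha-1D adrenergic receptor (Homo sapiens), read by radioligand binding (a higher number here means a weaker inhibitor, a lower number a stronger inhibitor), giving 0.43 nM. Compound 2, `COc1ccccc1N1CCN(CCCNc2c(C(C)=O)c(-c3ccccc3)nn(C)c2=O)CC1`, differs in more than one place and gives 4.32 nM, a gap beyond the usual scatter. Compound 3, `COc1ccccc1N1CCN(CCNc2cc(-c3ccccc3)nn(C)c2=O)CC1`, is not yet measured. It differs from compound 1 by hydrogen in place of isopropylcarbonyl on an aromatic carbon. No single change of this kind has been measured here, so the step is only estimated. Removing the isopropylcarbonyl is expected to weaken binding, with a step of a 7.0-fold higher number from compound 1 to compound 3 (0.84 log units; beyond the scatter). Compound 3 is therefore expected to give about 3 nM, within 0.8 nM to 12 nM.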

Compound 3, inhibition constant: 11.8 nM
Beside the measured number, compound 3's estimate is 3.9-fold (0.59 log units) below it; the measured number falls inside the stated range.
By their numbers in this assay, from the lowest: compound 1; then compound 2; then compound 3.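

In this assay, going by these compounds alone, hydrogen in place of isopropylcarbonyl on this aromatic carbon gives a 27-fold higher number from compound 1 to compound 3 (1.44 log units; beyond the scatter), the first change at a single place in this set. This position therefore matters for binding, although compound 3, with no group there, still gives 11.8 nM. Nothing available explains the size of this step. The compounds shown leave open whether the carbonyl or the isopropyl part carries the gain. A methyl, an amine or a carboxylic acid on this carbon would help separate those two parts.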